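A few compounds are considered here, and "the series" means these few. Any claim that something is new, unique, unknown or untested is made for them only; others in the source may bear on it.

Three compounds have been measured in a functional assay on SK-BR-3 cells (Homo sapiens) for antiproliferative activity, read by MTT assay, with a stated time of 72 h; a lower number here means a stronger inhibitor, a higher number a weaker inhibitor:

compound 1 `C/C=C1/[C@H](O[C@@H]2O[C@H](CO)[C@@H](O)[C@H](O)[C@H]2O)OC=C(C(=O)OC)[C@H]1CC(=O)OCCc1ccc(OC)cc1`: > 20000 nM, a limit
compound 2 `C/C=C1/[C@H](O[C@@H]2O[C@H](COC(C)=O)[C@@H](OC(C)=O)[C@H](OC(C)=O)[C@H]2OC(C)=O)OC=C(C(=O)OC)[C@H]1CC(=O)OC`: > 15000 nM, a limit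
compound 3 `C/C=C1/[C@H](O[C@@H]2O[C@H](CO)[C@@H](O)[C@H](O)[C@H]2O)OC=C(C(=O)OC)[C@H]1CC(=O)OCCc1ccc(O)cc1`: > 20000 nM, a limit

None of the three gave a number. For compound 1 the result in this assay is only a limit, > 20000 nM. For compound 3 the result is likewise only a limit, > 20000 nM. For compound 2 the result is again a limit, > 15000 nM.

Compound 3 differs from compound 1 by hydrogen in place of methyl on an oxygen on an aromatic ring. The step that the two limits leave unreadable from compound 1 to compound 3 cannot be read because the limit of > 20000 nM in this assay, at which 2 of the 3 values shown sit, holds both of its values. The difference between the cores of compound 1 and compound 2 is not broken down here.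

Compound 4 `C/C=C1/[C@H](O[C@@H]2O[C@H](COC(C)=O)[C@@H](OC(C)=O)[C@H](OC(C)=O)[C@H]2OC(C)=O)OC=C(C(=O)O)[C@H]1CC(=O)OC` has not yet been measured. It differs from compound 2 by hydrogen in place of methyl on an oxygen next to a carbonyl group. For the measured compounds named here, this is the same kind of change as the one from compound 1 to compound 3, not the same: there the place is an oxygen on an aromatic ring whose other neighbour is an aromatic carbon, here it is an oxygen next to a carbonyl group whose other neighbour is the carbonyl carbon.

The step that the limit leaves unreadable from compound 2 to compound 4 is expected to be small, resting on compound 2 sitting at the limit of > 15000 nM in this assay, at which 1 of the 3 values shown sits, and on the earlier step being unreadable. Compound 4 is therefore expected to give about 25000 nM in this assay, within 8000 nM to 80000 nM, most probably again only as a limit.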

Compound 4, half-maximal inhibitory concentration: > 20000 nM
Compound 4: a limit, no number; the forecaster's own chance of this, stated with the estimate: 85%; the middle value lies beyond the limit too.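

In this assay compound 4 gives > 20000 nM, which is a limit and not a number. Compound 2 also gives only a limit, > 15000 nM. For the compounds shown here, no step can therefore be read for the change from methoxycarbonyl to carboxy between compound 2 and compound 4. The compounds shown leave open the actual value of any of them in this assay, and so whether either change alters it at all.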